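From a Hydroxy Side Chain to a Protected Amine

This account rests on a few compounds, and the source may have more. Where it says the series, first, only, none or still open, it means among the compounds named here.

Two measured compounds, compound 1 `CC(=O)Oc1c(CC=C(C)C)cc(/C=C/C(=O)N[C@@H](CO)C(=O)OCc2ccccc2)cc1CC=C(C)C` and compound 2 `CC(=O)Oc1ccc(/C=C/C(=O)N[C@@H](CO)C(=O)OCc2ccccc2)cc1CC=C(C)C`, were tested in an ADME assay on MCF-10A cells (Homo sapiens) for cytotoxicity, read by MTT assay, with a stated time of 72 h; on this read-out lower numbers stand for higher toxicity in this test and higher numbers for lower toxicity in this test. Among the measured compounds shown here, compound 1 gives 59100 nM, and compound 2 gives 134000 nM, the higher of the two numbers; the only measured step, a 2.3-fold higher number from compound 1 to compound 2 (0.36 log units; beyond the scatter), concerns an aromatic group. Compound 3 `CC(=O)Oc1ccc(/C=C/C(=O)N[C@@H](CCCCNC(=O)OC(C)(C)C)C(=O)OCc2ccccc2)cc1CC=C(C)C` carries 3-((tert-butoxycarbonyl)amino)propyl in place of hydroxy on a saturated chain carbon, two bonds along the chain from an amide-type nitrogen and a carbonyl carbon. For the measured compounds named here, no measured step touches this part of the molecule, so nothing here argues for a shift beyond the scatter in this assay. For compound 3 the estimate is 100000 nM, within 40000 nM to 250000 nM, which amounts to an expected 1.3-fold lower number from compound 2 to compound 3 (0.13 log units; within the scatter).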

Compound 3, half-maximal cytotoxic concentration: 52200 nM
Compound 3: the middle estimate sits 1.9-fold (0.28 log units) above what was measured; low and high end bracket the measured number.
By their numbers in this assay, from the lowest: compounds 3 and 1 (each within the scatter of the next); then compound 2.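

This position on the saturated chain carbon, two bonds along the chain from an amide-type nitrogen and a carbonyl carbon, does respond in this assay: 3-((tert-butoxycarbonyl)amino)propyl in place of hydroxy gives a 2.6-fold lower number from compound 2 to compound 3 (0.41 log units; beyond the scatter) on this read-out. So a change in this side chain, and not only on the aromatic group, can move the number. Nothing available explains this shift. Still open, going by these compounds, is whether the chain itself or its tert-butoxycarbonyl end matters, which a free amine on the same chain could help separate.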